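Cyclopentyl in place of thiophenylmethyl on the amine

The source may hold more compounds than are shown below. What is called first, only, known or untested is meant among the compounds shown, and "the series" means these compounds.

Measured compounds:
- Compound 1 `COc1ccc(-c2cnc3nc(N)nc(NC(C)C)c3n2)cc1OC` gives 600 nM in a functional assay on cells (T-cell, Homo sapiens) for inhibition; a higher number here means a weaker inhibitor, a lower number a stronger inhibitor.
- Compound 2 `COc1ccc(-c2cnc3nc(N)nc(NCc4ccccc4)c3n2)cc1OC` gives 13000 nM in this assay.
- Compound 3 `COc1ccc(-c2cnc3nc(N)nc(NCc4cccs4)c3n2)cc1OC` gives 4100 nM in this assay.

All three share one core and differ only in the group carried on a nitrogen on an aromatic ring. Compound 3 stands second highest of the three numbers: a 3.2-fold lower number from compound 2 to compound 3 (0.50 log units; beyond the scatter) and a 6.8-fold higher number from compound 1 to compound 3 (0.83 log units; beyond the scatter). Compound 4 `COc1ccc(-c2cnc3nc(N)nc(NC4CCCC4)c3n2)cc1OC` is not yet measured. It differs from compound 3 in this way: cyclopentyl in place of (thiophen-2-yl)methyl on a nitrogen on an aromatic ring.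

Going by the values given here, the steps that bear on this change are those away from compound 1, which carries isopropyl: a 22-fold higher number from compound 1 to compound 2 (1.34 log units; beyond the scatter) and a 6.8-fold higher number from compound 1 to compound 3 (0.83 log units; beyond the scatter). Both groups with an aromatic ring gave higher numbers than isopropyl. Cyclopentyl, like isopropyl, carries no aromatic ring and no hydrogen-bond acceptor, so compound 4 is expected to move back toward compound 1 and give a lower number than compound 3, with an expected step of a 4.6-fold lower number from compound 3 to compound 4 (0.66 log units; beyond the scatter) in this assay. Compound 4 is therefore estimated at 900 nM, with a range from 300 nM to 3000 nM.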

Compound 4, half-maximal inhibitory concentration: 800 nM
Compound 4: middle estimate off by 1.1-fold (0.05 log units), on the high side; low and high end bracket the measured number.
By their numbers in this assay, from the lowest: compounds 1 and 4 (each within the scatter of the next); then compound 3; then compound 2.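

In this assay, a ring on the amine nitrogen does not by itself bring a high number: the carbon-only ring of cyclopentyl gives a 5.1-fold lower number from compound 3 to compound 4 (0.71 log units; beyond the scatter) and, against benzyl, a 16-fold lower number from compound 2 to compound 4 (1.21 log units; beyond the scatter) as the result. Isopropyl and cyclopentyl cannot be told apart here, with a 1.3-fold higher number from compound 1 to compound 4 (0.12 log units; within the scatter) as their step, so this position accepts the larger carbon-only ring without a change beyond the scatter. No measurement shown explains these differences.

Cyclopentyl differs from benzyl and (thiophen-2-yl)methyl both in lacking an aromatic ring and in attaching directly through its ring, so these two changes remain tied together; cyclopentylmethyl would separate them. From the compounds shown here alone, whether a larger ring such as cyclohexyl, or a hydroxyl or an amine on the cyclopentyl ring, would be accepted also remains open.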